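The source may hold more compounds than are shown below. What is called first, only, known or untested is meant among the compounds shown, and "the series" means these compounds.

Working notes on the series, measured in a physicochemical assay for solubility; a higher number here means a more soluble compound, a lower number a less soluble compound:
- compound 1 `COc1ccc(-n2cnc3cnc(Nc4cccc(NS(C)(=O)=O)c4)cc32)cc1OC` gives > 200000 nM as a limit of the assay, not a number
- compound 2 `COc1ccc(-n2cnc3cnc(Oc4cccc(NC(C)=O)c4)cc32)cc1OC` gives > 200000 nM as a limit of the assay, not a number
- compound 3 `COc1ccc(-n2cnc3cnc(-c4cccc(NC(C)=O)c4)cc32)cc1OC` gives 146000 nM as a measured number

Not yet measured: compound 4 `COc1ccc(-n2cnc3cnc(-c4ccccc4)cc32)cc1OC`.

The set is defined mainly by the limit of > 200000 nM in this assay, at which 2 of the 3 values shown sit, and so offers little to compare. Among the compounds with values here, compound 3 stands alone with 146000 nM as the only true number in this assay, and no order among the three compounds is claimed.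

The step of interest puts hydrogen in place of acetamido on an aromatic carbon. The change is on a six-membered aromatic ring of carbon only, meta to a large group. Within the data shown here, no pair of measured compounds differs in one place, so nothing sizes this change directly, and the expectation that follows is a judgement starting from compound 3 at 146000 nM in this read-out.

A fall in this assay beyond the usual scatter is expected, moderate rather than extreme in size. The expected step is a 3.7-fold lower number from compound 3 to compound 4 (0.56 log units; beyond the scatter) and it remains an estimate. Compound 4 is estimated at 40000 nM with an expected range from 8000 nM to 130000 nM until the measurement is in.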

Compound 4, solubility: 28000 nM
For compound 4 the middle estimate is 1.4-fold (0.15 log units) above the measured one; the measured number falls inside the stated range.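

In this assay, within the data shown here, hydrogen in place of acetamido on an aromatic carbon of a six-membered aromatic ring of carbon only, meta to a large group, gives a 5.2-fold lower number from compound 3 to compound 4 (0.72 log units; beyond the scatter) as the first step that can be sized. The position is therefore not silent in this read-out: with the shared core held constant, taking away acetamido alone gives a change beyond the scatter, and the direction of that change is now measured rather than estimated. Steps involving compound 1 or compound 2 cannot be read, and their values remain limits of the assay rather than numbers: the limit of > 200000 nM in this assay, at which 2 of the 4 values shown sit.

One pair cannot separate the acetamido group as a whole from any one of its parts, and it gives no cause for the step; an amine, a carboxylic acid or a longer chain on the same carbon would show whether the number follows the group's identity or merely the presence of something other than hydrogen. On these data alone, it also remains open whether the step carries over to the oxygen-linked ring of compound 2 or the nitrogen-linked ring of compound 1.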